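Working notes on a small whole-plant inhibition series

The source may report more compounds than this note shows. Statements on the series, on what has been measured and on what is new or still open speak of the compounds shown alone.

Measured so far:
- compound 1, `Cc1nc(Nc2ccc(O)cc2)c2cc[nH]c2n1`, in a functional assay on the whole organism for inhibition, with Nicotiana tabacum as the target; on this read-out higher numbers stand for weaker inhibition and lower numbers for stronger inhibition: 155000000 nM
- compound 2, `Cc1nc(NCCCO)c2cc[nH]c2n1`, in this assay: 17800000 nM

Compound 2 holds the lower of the two numbers in this assay; compound 1 sits above it by a gap that lies beyond the usual scatter. Nothing more can be said of that pair, as the two structures differ in more than one place.

Compound 3, `Cc1nc(NCC(C)(C)C)c2cc[nH]c2n1`, is the next compound to go into this assay. It differs from compound 2 in one place: tert-butyl in place of 2-hydroxyethyl on a saturated chain carbon bound to a nitrogen on an aromatic ring. Going by the values given here, no step between measured compounds resembles this change, so the expectation rests on compound 2 alone. For compound 3 a small step from compound 2 is expected, a 1.6-fold higher number from compound 2 to compound 3 (0.20 log units; within the scatter), leaning toward a weaker number but plausibly within the scatter. The estimate for compound 3 in this assay is 28000000 nM, with a range from 7000000 nM to 110000000 nM.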

Compound 3, half-maximal inhibitory concentration: 200000000 nM
For compound 3 the middle estimate is 7.1-fold (0.85 log units) below the measured one, and the stated range ends below it.
By their numbers in this assay, from the lowest: compound 2; then compounds 1 and 3 (each within the scatter of the next).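

Tert-butyl in place of 2-hydroxyethyl gives an 11-fold higher number from compound 2 to compound 3 (1.05 log units; beyond the scatter) in this assay, so this place on the chain is not indifferent to the group it carries. With this single pair, the loss of the hydroxyl-bearing end, with its hydrogen-bond donor and acceptor, and the arrival of an all-carbon end go with weaker inhibition. Nothing available on these compounds bears on why the number moves this far.

The pair changes both the oxygen and the branching at once, so the step cannot yet be assigned to either one; an unbranched propyl chain, an amine or a carboxylic acid at the chain end would help separate them. On these data alone, whether a longer hydroxyalkyl chain would lower the number further also remains open.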